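Acyl variation on a cyanoguanidine pyridine antihypertensive

The source may report more compounds than this note shows. Statements on the series, on what has been measured and on what is new or still open speak of the compounds shown alone.

The measured compounds:
compound 1, `CC(C)(C)/N=C(\NC#N)Nc1ccncc1`, 2.5 mg/kg
compound 2, `CC(=O)N(/C(=N\C#N)Nc1cccnc1)C(C)(C)C`, 0.1 mg/kg

Of the compounds shown here, two have been measured in a functional assay on the whole organism (blood, strain Wistar-Okamoto) with Rattus norvegicus as the target, with a stated time of 5 days; on this read-out higher numbers stand for an effect only at larger amounts of compound and lower numbers for an effect already at smaller amounts. Compound 1 gives 2.5 mg/kg in this assay, while compound 2 gives 0.1 mg/kg. Compound 2 thus stands at the lowest of the two numbers, and the gap to compound 1 lies well beyond the scatter of repeated measurements. Since the two differ in several places at once, only their two values can be compared.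

Compound 3, `CC(C)C(=O)N(/C(=N\C#N)Nc1cccnc1)C(C)(C)C`, has not yet been measured. It differs from compound 2 in one place: isopropyl in place of methyl on a carbonyl carbon. Among the compounds with values here, no step between measured compounds covers such a change, so compound 3 is expected to keep close to compound 2, with a step of a 1.5-fold higher number from compound 2 to compound 3 (0.18 log units; within the scatter) in this assay that stays within or only just beyond the scatter. Compound 3 is therefore estimated at 0.15 mg/kg, within a range from 0.05 mg/kg to 0.5 mg/kg.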

Compound 3, minimum effective dose: 10 mg/kg
Beside the measured number, compound 3's estimate is 67-fold (1.82 log units) below it; measured number above the stated range.
By their numbers in this assay, from the lowest: compound 2; then compound 1; then compound 3.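

In this assay, the carbonyl carbon whose other neighbour is the amide-type nitrogen proves highly sensitive to change: isopropyl in place of methyl gives a 100-fold higher number from compound 2 to compound 3 (2.00 log units; beyond the scatter). Within the data shown here, this is the first single-place step available for this series, and it shows that acetyl to isopropylcarbonyl, a change that adds only carbon and no hydrogen-bond donors, hydrogen-bond acceptors or net charge, is enough to shift the effect to much larger amounts of compound. Nothing available explains this shift.

The compounds shown leave open how the number moves between methyl and isopropyl, for instance with an ethyl group on the carbonyl carbon, and whether a longer chain or an amine there would read more like methyl or like isopropyl. On these data alone, what the acetyl group itself contributes also remains unknown, since compound 1 and compound 2 differ in several places at once.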